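The source may report more compounds than this note shows. Statements on the series, on what has been measured and on what is new or still open speak of the compounds shown alone.

Compound 3 `CS(=O)(=O)Nc1ccc2c(c1)S(=O)(=O)N=C(c1c(O)c(-c3cccs3)nn(CCC3CC3)c1=O)N2` has been tested in an in vitro ADME assay on microsomes from liver (Homo sapiens) for metabolic stability, tested at 5 uM; a lower number here means that the compound disappears faster, a higher number that the compound lasts longer. In this assay compound 3 gives only a limit, > 1 h, not a measured number (the limit of > 1 h in this assay, at which 1 of the 3 values shown sits). Two companions give full numbers in this assay: compound 1 `CC(C)CCn1nc(-c2ccn(C)c2)c(O)c(C2=NS(=O)(=O)c3cc(NS(C)(=O)=O)ccc3N2)c1=O` gives 0.633 h, and compound 2 `CCC(C)(C)c1nn(CCC(C)C)c(=O)c(C2=NS(=O)(=O)c3cc(NS(C)(=O)=O)ccc3N2)c1O` gives 0.1 h. Going by the values given here, the one measured step, a 6.3-fold lower number from compound 1 to compound 2 (0.80 log units; beyond the scatter), exchanges a group on an aromatic carbon and leaves the chain untouched, so it does not speak directly to the change at hand. Compound 4 `CS(=O)(=O)Nc1ccc2c(c1)S(=O)(=O)N=C(c1c(O)c(-c3cccs3)nn(CCC3CCCCC3)c1=O)N2` differs from compound 3 by cyclohexyl in place of cyclopropyl on a saturated chain carbon, two bonds along the chain from an aromatic nitrogen. Among the compounds with values here, with no measured step covering this change, and compound 3 sitting at a limit, the number for compound 4 is expected to stay near or somewhat under that limit. Compound 4 is estimated at 0.7 h, within 0.3 h to 1.5 h. That estimate corresponds to an at least 1.4-fold lower number from compound 3 to compound 4 (0.15 log units; that floor lies within the scatter).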

Compound 4, half-life: > 1 h
Compound 4: a limit, no number; the forecaster's own chance of this, stated with the estimate: 35%; middle value at least 1.4-fold (0.15 log units) away from the limit.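

Compound 3 and compound 4 both stop at a limit in this assay, so the change from cyclopropyl to cyclohexyl cannot be read as a step: the limit of > 1 h in this assay, at which 2 of the 4 values shown sit.

From the compounds shown here alone, how long each compound actually lasts, and whether the two differ at all, stays open.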